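The source may report more compounds than this note shows. Statements on the series, on what has been measured and on what is new or still open speak of the compounds shown alone.

Measured in a functional assay (aorta) with Rattus norvegicus as the target; on this read-out lower numbers stand for stronger inhibition and higher numbers for weaker inhibition:
- Compound 1 `CC1(C)Oc2ccc(C#N)cc2[C@@H](/N=C(\NC#N)Nc2ccccc2)[C@@H]1O`: 1400 nM; 1300 nM (2 entries)
- Compound 2 `CC1(C)Oc2ccc(C#N)cc2[C@@H](/N=C(\NC#N)Nc2cccc([N+](=O)[O-])c2)[C@@H]1O`: 670 nM
- Compound 3 `CC1(C)Oc2ccc(C#N)cc2[C@@H](/N=C(\NC#N)Nc2ccc(C(F)(F)F)cc2)[C@@H]1O`: 8100 nM

Of these three, compound 3 has the highest number in this assay, at 8100 nM. Compound 4 `COC(=O)c1cccc(N/C(=N/[C@@H]2c3cc(C#N)ccc3OC(C)(C)[C@H]2O)NC#N)c1` keeps the shared core and differs from compound 3 in one place: 3-(methoxycarbonyl)phenyl in place of 4-(trifluoromethyl)phenyl on an amine nitrogen.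

For the measured compounds named here, only one measured step bears on this change: a 12-fold higher number from compound 2 to compound 3 (1.08 log units; beyond the scatter). That step is large, lies beyond the scatter and arrives at the 4-(trifluoromethyl)phenyl group that compound 4 gives up. Going by the values given here, no compound carrying the 3-(methoxycarbonyl)phenyl group has been measured, so the size of the change remains uncertain. Even so, compound 2 at 670 nM and compound 1 at 1400 nM; 1300 nM (2 entries) both lie well under compound 3, which suggests a sizeable move towards lower numbers. The expected change in this assay is a 7.4-fold lower number from compound 3 to compound 4 (0.87 log units; beyond the scatter). The estimated value for compound 4 is 1100 nM. The expected range runs from 350 nM to 3500 nM.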

Compound 4, half-maximal inhibitory concentration: 4100 nM
Compound 4: the middle estimate sits 3.7-fold (0.57 log units) below what was measured; measured number outside the range, above it.
By their numbers in this assay, from the lowest: compound 2; then compounds 4 and 3 (each within the scatter of the next).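

In this assay, the 3-(methoxycarbonyl)phenyl group in place of the 4-(trifluoromethyl)phenyl group on the amine nitrogen gives a 2.0-fold lower number from compound 3 to compound 4 (0.30 log units; within the scatter), so these two groups cannot be told apart on this read-out. Methoxycarbonyl in place of nitro on an aromatic carbon gives a 6.1-fold higher number from compound 2 to compound 4 (0.79 log units; beyond the scatter), which shows that the read-out responds to this exchange of one group for another on the phenyl ring. Compound 2 is thereby set apart from both compound 3 and compound 4, so the lower number of compound 2 is not shared by every substituted phenyl group shown.

The compounds shown leave open whether an amine or a carboxylic acid in place of the nitro group would fall nearer compound 2 or compound 4. Nothing shown gives a reason for the gap between the nitro and methoxycarbonyl compounds.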